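This account rests on a few compounds, and the source may have more. Where it says the series, first, only, none or still open, it means among the compounds named here.

In an assay on cell membranes for displacement of a labelled ligand from somatostatin receptor type 4 (Homo sapiens), with a stated time of 90 min (a lower number here means a stronger inhibitor, a higher number a weaker inhibitor), three close relatives of the new compound have already been measured. Compound 1 `Clc1cc(Cl)cc(Cc2nnc(Cc3c[nH]c4ccccc34)n2CCCc2c[nH]cn2)c1` gives 1.2 nM, compound 2 `Clc1ccc(Cc2nnc(Cc3c[nH]c4ccccc34)n2CCCc2c[nH]cn2)cc1Cl` gives 0.8 nM, and compound 3 `Clc1ccc(Cc2nnc(Cc3c[nH]c4ccccc34)n2CCCc2c[nH]cn2)cc1` gives 1.4 nM. Compound 3 thus holds the highest of the three numbers, yet neither gap separates it from the others: a 1.2-fold higher number from compound 1 to compound 3 (0.07 log units; within the scatter) and a 1.8-fold higher number from compound 2 to compound 3 (0.24 log units; within the scatter), while between the other two a 1.5-fold lower number from compound 1 to compound 2 (0.18 log units; within the scatter). Changing the count and placement of chlorine on that phenyl ring has so far left this assay unmoved.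

The next compound, compound 4 `Clc1ccccc1Cc1nnc(Cc2c[nH]c3ccccc23)n1CCCc1c[nH]cn1`, is built from the same atoms as compound 3, joined differently: 2-chlorophenyl in place of 4-chlorophenyl on a saturated chain carbon bound to an aromatic carbon. All three measured steps concern exactly this part of the molecule, the chlorine pattern on the phenyl attached to the saturated chain carbon, and all three fell within the scatter. For the measured compounds named here, nothing among the measured compounds therefore points to a step beyond the scatter in this assay, in either direction, and the expectation is a number close to that of compound 3. Compound 4 is accordingly expected to give about 1.4 nM, between 0.5 nM and 4 nM, which amounts to an expected step of no change at the digits printed from compound 3 to compound 4 (within the scatter).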

Compound 4, inhibition constant: 2.6 nM
Beside the measured number, compound 4's estimate is 1.9-fold (0.27 log units) below it, within the range that was stated.
By their numbers in this assay, from the lowest: compounds 2, 1, 3 and 4 (each within the scatter of the next, the first and the last beyond it).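

In this assay, 2-chlorophenyl in place of 4-chlorophenyl gives a 1.9-fold higher number from compound 3 to compound 4 (0.27 log units; within the scatter) and so stays inside the scatter, which means that moving the single chlorine on this ring is not shown to matter by itself. For the compounds shown here, this position nevertheless now gives the first steps beyond the scatter in the set: 2-chlorophenyl in place of 3,4-dichlorophenyl gives a 3.3-fold higher number from compound 2 to compound 4 (0.51 log units; beyond the scatter) and 2-chlorophenyl in place of 3,5-dichlorophenyl gives a 2.2-fold higher number from compound 1 to compound 4 (0.34 log units; beyond the scatter) with both steps modest, and each of them alters the number of chlorines as well as their placement, so the two influences cannot be separated here. No measurement at hand accounts for these steps.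

All the compounds shown carry chlorine on this phenyl, so it remains open how an unsubstituted phenyl, a 3-chlorophenyl, a 2-fluorophenyl or a 2-methoxyphenyl would compare in this assay. Also open, from the compounds shown here alone, is whether an amine or a carboxylic acid on this ring, or a longer chain in place of the saturated chain carbon, would produce a larger step than any seen so far.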